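From a piperidine to an isopropylpiperazine side chain

A few compounds are considered here, and "the series" means these few. Any claim that something is new, unique, unknown or untested is made for them only; others in the source may bear on it.

Measured in an ADME assay on microsomes from liver (Rattus norvegicus) for metabolic stability, read by LC-MS, with a stated time of 10 min, tested at 0.5 uM; on this read-out lower numbers stand for a less stable compound and higher numbers for a more stable compound:
compound 1 `c1ccc2c(c1)CN[C@@H](CN(CC1CCNCC1)[C@H]1CCCc3cccnc31)C2`: 65%
compound 2 `c1ccc2c(c1)CN[C@@H](CN(CC[C@@H]1CCCNC1)[C@H]1CCCc3cccnc31)C2`: 28%

Compound 2, at 28%, holds the lower of the two numbers in this assay, while compound 1, the higher of the two by a wide margin, gives 65%. The next structure, compound 3 `CC(C)N1CCN(CCCN(C[C@H]2Cc3ccccc3CN2)[C@H]2CCCc3cccnc32)CC1`, keeps the shared core and alters the side chain: (4-isopropylpiperazin-1-yl)methyl in place of piperidin-3-yl on a saturated chain carbon, two bonds along the chain from an amine nitrogen. In words, (4-isopropylpiperazin-1-yl)methyl stands in place of piperidin-3-yl on a saturated chain carbon, two bonds along the chain from an amine nitrogen.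

Among the compounds with values here, only one measured step bears on this change: a number 37 percentage points lower from compound 1 to compound 2 (beyond the scatter). This large step, beyond the scatter, shows that a change in the side chain can move the number considerably. It involved different groups, however, so it indicates neither a direction nor a size for the new change. The data therefore give no firm reason to expect a step beyond the scatter, although the uncertainty is wide. The expected change is a number 3 percentage points lower from compound 2 to compound 3 (within the scatter). The estimated value for compound 3 is 25%, with an expected range of 8% to 50%.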

Compound 3, percent of the compound remaining: 4%
The estimate for compound 3 lay 21 percentage points above the measured number; measured number outside the range, below it.
By their numbers in this assay, from the lowest: compound 3; then compound 2; then compound 1.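

In this assay, (4-isopropylpiperazin-1-yl)methyl in place of piperidin-3-yl on a saturated chain carbon, two bonds along the chain from an amine nitrogen, gives a number 24 percentage points lower from compound 2 to compound 3 (beyond the scatter), so the number at this position can fall further even from the low value of compound 2. Read from the other measured side chain, 2-(4-isopropylpiperazin-1-yl)ethyl in place of piperidin-4-yl on a saturated chain carbon bound to an amine nitrogen gives a number 61 percentage points lower from compound 1 to compound 3 (beyond the scatter), and with both steps beyond the scatter, compound 3 stands lowest of the three in this series. No measurement at hand accounts for either fall.

The second ring nitrogen, the isopropyl group and the added atoms of the side chain all enter together in compound 3, so the compounds shown do not tell which of them goes with the lower number. An unsubstituted piperazine or a morpholine carried on the same ethyl chain would separate these parts, and a (4-isopropylpiperazin-1-yl)methyl group set directly in place of piperidin-4-yl would test the chain length.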